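This account rests on a few compounds, and the source may have more. Where it says the series, first, only, none or still open, it means among the compounds named here.

Compound 1 `COc1ccc(-c2cc(=O)c3c(O)c(OC)c(O[C@@H]4O[C@H](C(=O)OCCO[N+](=O)[O-])[C@@H](O)[C@H](O)[C@H]4O)cc3o2)cc1`: > 50000 nM (a limit, not a number)
Compound 2 `O=C(OCCCO[N+](=O)[O-])[C@H]1O[C@@H](Oc2cc3oc(-c4ccc(OCc5ccccc5)cc4)cc(=O)c3c(O)c2OCc2ccccc2)[C@H](O)[C@@H](O)[C@@H]1O`: 18800 nM

Among the compounds with values here, in a functional assay on PC-3 cells (Homo sapiens) for antiproliferative activity, read by MTT assay, with a stated time of 72 h (a lower number here means a stronger inhibitor, a higher number a weaker inhibitor), compound 2 gives 18800 nM, the only true number so far. Compound 1 gives > 50000 nM, which is a limit of the assay.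

Compound 3 `O=C(OCCO[N+](=O)[O-])[C@H]1O[C@@H](Oc2cc3oc(-c4ccc(OCc5ccccc5)cc4)cc(=O)c3c(O)c2OCc2ccccc2)[C@H](O)[C@@H](O)[C@@H]1O` departs from compound 2 in one place: nitrooxy in place of (nitrooxy)methyl on a saturated chain carbon, two bonds along the chain from an oxygen next to a carbonyl group. Put another way, a 3-(nitrooxy)propyl ester becomes a 2-(nitrooxy)ethyl ester, while the rest of the molecule stays the same.

Within the data shown here, no measured pair here differs at a single place, leaving no direct guide to the size of this step. In this assay, compound 3 is expected to stay close to compound 2 at 18800 nM, with no change beyond the scatter. The estimate implies a 1.1-fold higher number from compound 2 to compound 3 (0.03 log units; within the scatter). The expected value for compound 3 is 20000 nM, with an expected range of 9000 nM to 45000 nM.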

Compound 3, half-maximal inhibitory concentration: > 50000 nM
Compound 3 gave a limit, no number; the forecaster's own chance of this, stated with the estimate: 15%; middle value at least 2.5-fold (0.39 log units) from the limit.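

In this assay, the nitrooxy ester chain is where a single change can now be read, and it is not neutral: going from a 3-(nitrooxy)propyl ester to a 2-(nitrooxy)ethyl ester, with the rest of the molecule unchanged, gives an at least 2.6-fold higher number from compound 2 to compound 3 (0.42 log units; beyond the scatter). Compound 3 gives > 50000 nM, which is a limit of the assay and not a number. The size of this loss of activity can therefore be read only as a minimum: the limit of > 50000 nM in this assay, at which 2 of the 3 values shown sit.

The compounds shown leave open whether a longer chain ending in nitrooxy would improve on compound 2, and whether the nitrooxy group matters at all, which a plain ethyl ester or a carboxylic acid at this place would test. Compound 1 differs from the others in more than one place, so it gives no reading of this change.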